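This account rests on a few compounds, and the source may have more. Where it says the series, first, only, none or still open, it means among the compounds named here.

Compound 1, `Clc1cccc(Nc2ncnc3ccc(NCc4ccc5c(c4)OCCCO5)cc23)c1`, in a functional assay on A549 cells (Homo sapiens) for antiproliferative activity, read by WST assay, with a stated time of 48 h; on this read-out higher numbers stand for weaker inhibition and lower numbers for stronger inhibition: 31 ug/mL
Compound 2, `O=C(Nc1ccc2ncnc(Nc3cccc(Br)c3)c2c1)C1COc2ccccc2O1`, in this assay: 73.8 ug/mL

Of these two, compound 2 stands with the higher number, which on this read-out means the weaker inhibition of cell growth. Compound 1 sits lower, and the gap between the two numbers is wider than what repeated measurements of this kind usually scatter over. The two compounds differ at several points, so no single cause for that gap can be read from them.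

Compound 3, `O=C(Nc1ccc2ncnc(Nc3cccc(Cl)c3)c2c1)C1COc2ccccc2O1`, is the same as compound 2 except for one change: chloro in place of bromo on an aromatic carbon. Among the compounds with values here, nothing among the measured pairs shows what this swap does here, since no two measured compounds differ by exactly this exchange. Swaps of one halogen for another at such a position often move the number only a little, so the step is expected to be small, with no clear direction beyond the scatter. The expected step of a 1.1-fold lower number from compound 2 to compound 3 (0.06 log units; within the scatter) is therefore close to none. Compound 3 is expected to give about 65 ug/mL, estimated between 28 ug/mL and 150 ug/mL.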

Compound 3, half-maximal inhibitory concentration: 61.2 ug/mL
For compound 3 the middle estimate is 1.1-fold (0.03 log units) above the measured one; low and high end bracket the measured number.
By their numbers in this assay, from the lowest: compounds 1, 3 and 2 (each within the scatter of the next, the first and the last beyond it).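

In this assay, the change from 3-bromophenyl to 3-chlorophenyl gives a 1.2-fold lower number from compound 2 to compound 3 (0.08 log units; within the scatter). This is the first pair shown that differs in only one place, so it gives the first direct reading at this position: on this aromatic ring, meta to a large group, this assay does not tell chloro and bromo apart. Nothing measured here offers an explanation for why the two halogens read alike.

The compounds shown carry only these two halogens at this position, so what a smaller fluoro, a methyl, a methoxy or an amine would do there remains open. This single pair also cannot show whether the exchange would read the same with the different side chain of compound 1, since that compound has no direct halogen partner among those shown.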